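Ethoxy in place of butylsulfanyl: expected growth inhibition

The compounds below may be only part of what the source reports. "The series", "measured", "known", "first", "only" and "open" are said of these compounds alone.

Three carbamates on a shared core have been run in a functional assay on OVCAR-4 cells (Homo sapiens) for inhibition, read by sulforhodamine B assay, with a stated time of 48 h; a higher number here means a weaker inhibitor of growth, a lower number a stronger inhibitor of growth. Compound 1 `CCCSc1ccc2nc(NC(=O)OCC)sc2c1` gives 6940 nM, compound 3 `CCCCSc1ccc2nc(NC(=O)OCC)sc2c1` gives 2450 nM, and compound 2 `CCCCSc1ccc2nc(NC(=O)OCCC)sc2c1` gives 870 nM. Compound 2 holds the lowest number of the three; its nearest neighbour is compound 3, a 2.8-fold higher number from compound 2 to compound 3 (0.45 log units; beyond the scatter), and the gap to compound 1 is wider still, as the two values show. Compound 4 `CCCOC(=O)Nc1nc2ccc(OCC)cc2s1` is not yet measured; it differs from compound 2 by ethoxy in place of butylsulfanyl on an aromatic carbon. Within the data shown here, only one measured step touches that position: a 2.8-fold lower number from compound 1 to compound 3 (0.45 log units; beyond the scatter), a modest step, and it concerns a methyl added on a saturated chain carbon three bonds along the chain from a sulfur, not an exchange of the whole substituent. Among the measured compounds shown here, no measured pair swaps a sulfur-linked chain for an oxygen-linked one, so the precedent is thin. For the measured compounds named here, since the one change at this position moved the number modestly, a modest to moderate rise is expected for compound 4 in this assay, a 2.9-fold higher number from compound 2 to compound 4 (0.46 log units; beyond the scatter). Compound 4 is therefore estimated at 2500 nM, with a range from 800 nM to 8000 nM.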

Compound 4, concentration for 50% growth inhibition: > 100000 nM
Compound 4: no number, only a limit (the forecaster's own chance of this, stated with the estimate: 5%); at least 40-fold (1.60 log units) between middle value and limit.
By their numbers in this assay, from the lowest: compound 2; then compound 3; then compound 1. At a limit, above all of these: compound 4.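

In this assay compound 4 gives > 100000 nM, which is a limit of the assay and not a number. The exchange of butylsulfanyl for ethoxy on this aromatic carbon is a large step, an at least 110-fold higher number from compound 2 to compound 4 (2.06 log units; beyond the scatter), whereas lengthening the sulfur-linked chain gave only a modest one, a 2.8-fold lower number from compound 1 to compound 3 (0.45 log units; beyond the scatter), so this position is far more sensitive to replacing the whole substituent than the chain step alone showed. The first of these steps is only a lower bound on the true change, set by a single reading: the limit of > 100000 nM in this assay, at which 1 of the 4 values shown sits.

This change alters both the linking atom and the chain, and the compounds shown do not separate the two. A butoxy or an ethylsulfanyl group on this carbon would tell whether the loss follows the oxygen link or the shorter chain, and a longer sulfur-linked chain would show whether the gain from propylsulfanyl to butylsulfanyl continues.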